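Carbamoyl in place of ring hydrogen: compound 3

A few compounds are considered here, and "the series" means these few. Any claim that something is new, unique, unknown or untested is made for them only; others in the source may bear on it.

Measured so far:
compound 1 `C[C@@H]1CCCN1c1c(C#N)c2c(N)ncnc2n1C` — 11 nM
compound 2 `C[C@@H]1CCCN1c1cc2c(N)ncnc2n1C` — 6390 nM

In an assay on isolated protein for inhibition of Leucine-rich repeat serine/threonine-protein kinase 2 variant G2019S (Homo sapiens), read by TR-FRET and LanthaScreen, with stated times of 50 min and 30 min, in the presence of a further agent that is not named here (on this read-out higher numbers stand for weaker inhibition and lower numbers for stronger inhibition), compound 1 gives 11 nM and compound 2 gives 6390 nM. Going by the values given here, compound 2 stands highest of the two numbers; the only step that reaches it is a 580-fold higher number from compound 1 to compound 2 (2.76 log units; beyond the scatter), a large loss that goes with the removal of the cyano group.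

Compound 3 `C[C@@H]1CCCN1c1c(C(N)=O)c2c(N)ncnc2n1C` carries the change (carbamoyl in place of hydrogen on an aromatic carbon). Among the compounds with values here, only one measured step bears on it: a 580-fold higher number from compound 1 to compound 2 (2.76 log units; beyond the scatter) shows how much a substituent at this carbon can matter in this assay. Carbamoyl is not cyano, so the full reverse of that step is not assumed, but a clear move towards lower numbers in this assay is expected. Compound 3 is estimated at 150 nM (range 25 nM to 900 nM). The expected step is a 43-fold lower number from compound 2 to compound 3 (1.63 log units; beyond the scatter).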

Compound 3, half-maximal inhibitory concentration: 2240 nM
Compound 3: the middle estimate sits 15-fold (1.17 log units) below what was measured; measured number above the stated range.
By their numbers in this assay, from the lowest: compound 1; then compound 3; then compound 2.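

In this assay, carbamoyl on this aromatic carbon recovers only a small part of the ground lost without cyano: a 2.9-fold lower number from compound 2 to compound 3 (0.46 log units; beyond the scatter), whereas a 200-fold higher number from compound 1 to compound 3 (2.31 log units; beyond the scatter). A low number at this carbon therefore does not follow from having just any substituent there, since among the groups shown only cyano reaches it, and carbamoyl stays much closer to the unsubstituted compound 2. Nothing available here accounts for the gap between cyano and carbamoyl.

Still open, from the compounds shown here alone, is where other groups on this carbon, such as chloro, methyl or a carboxylic acid, would fall relative to cyano and carbamoyl. Also open, going by these compounds, is whether cyano keeps its large lead over carbamoyl when another amine, such as morpholine, replaces the 2-methylpyrrolidin-1-yl group.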